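The source may hold more compounds than are shown below. What is called first, only, known or untested is meant among the compounds shown, and "the series" means these compounds.

Measured so far: compound 1 `CCOC(=O)c1csc(-c2nc3ccccc3n2Cc2ccccc2)n1` and compound 2 `Cc1nc(-c2nc3ccccc3n2Cc2ccccc2)sc1C(=O)NC(C)C`.

In a functional assay on MCF7 cells (Homo sapiens) for cytotoxicity, read by MTT assay, with a stated time of 24 h (on this read-out higher numbers stand for weaker inhibition and lower numbers for stronger inhibition), compound 1 gives only a limit, > 20000 nM; this is the limit of > 20000 nM in this assay, at which 1 of the 2 values shown sits. In this assay, going by the values given here, compound 2 gives 6640 nM, the only numeric value in the set.

Compound 3 `Cc1nc(-c2nc3ccccc3n2Cc2ccccc2)sc1C(=O)N1CCCCC1` differs from compound 2 by piperidin-1-yl in place of isopropylamino on a carbonyl carbon. Among the compounds with values here, no measured step covers this change, so in this assay the step from compound 2 to compound 3 is expected to be small, probably within the usual scatter, with at most a slight drift toward weaker inhibition. Compound 3 is estimated at 8500 nM, between 2500 nM and 25000 nM. The expected step is a 1.3-fold higher number from compound 2 to compound 3 (0.11 log units; within the scatter).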

Compound 3, half-maximal inhibitory concentration: > 20000 nM
Compound 3: no number, only a limit; the forecaster's own chance of this, stated with the estimate: 30%; at least 2.3-fold (0.37 log units) between middle value and limit.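

In this assay, piperidin-1-yl in place of isopropylamino on the carbonyl carbon gives an at least 3.0-fold higher number from compound 2 to compound 3 (0.47 log units; beyond the scatter), the first step read at this place, and it lies beyond the scatter. The change removes the hydrogen-bond donor and adds a six-membered ring, so a numeric value is retained only with isopropylamino among these two amides. Compound 3 gives a limit and not a number, so the full size of the step stays unread: the limit of > 20000 nM in this assay, at which 2 of the 3 values shown sit.

As far as these compounds go, it remains open whether the step follows the donor or the ring. Cyclohexylamino and dimethylamino on the same carbonyl carbon would separate the two.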